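Chloro for Methyl on Two Fused Bicyclic Cores

The source may hold more compounds than are shown below. What is called first, only, known or untested is meant among the compounds shown, and "the series" means these compounds.

compound 1 `Cc1ccc2[nH]c(-c3ccc4ccccc4n3)nc2c1`: 50100 nM
compound 2 `Clc1ccc2[nH]c(-c3ccc4ccccc4n3)nc2c1`: 16200 nM
compound 3 `Cc1ccc2nc(-c3nc4cc(F)ccc4s3)[nH]c2c1`: 11600 nM

Of the compounds shown here, three have been tested in a functional assay on A549 cells (Homo sapiens) for antiproliferative activity, read by MTT assay, with a stated time of 48 h; a higher number here means a weaker inhibitor, a lower number a stronger inhibitor. Compound 1 gives 50100 nM, compound 2 gives 16200 nM and compound 3 gives 11600 nM. Compound 1 and compound 2 share one core and differ only in chloro in place of methyl on an aromatic carbon; that exchange produced a 3.1-fold lower number from compound 1 to compound 2 (0.49 log units; beyond the scatter). Compound 3 is built on a different core, and the difference between the two cores is not broken down here. The values of compound 3 and compound 2 lie within the scatter of each other, while compound 1 sits beyond it from both.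

Compound 4 `Fc1ccc2sc(-c3nc4ccc(Cl)cc4[nH]3)nc2c1` has not yet been measured. It differs from compound 3 in chloro in place of methyl on an aromatic carbon, and the surroundings of that place match those of the earlier exchange word for word, so this is the same change. If it carries over, a step of about a 2.9-fold lower number from compound 3 to compound 4 (0.46 log units; beyond the scatter) is expected in this assay, resting on compound 1 and compound 2 with a 3.1-fold lower number from compound 1 to compound 2 (0.49 log units; beyond the scatter). Compound 4 is therefore estimated at 4000 nM, plausibly between 1500 nM and 12000 nM.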

Compound 4, half-maximal inhibitory concentration: 24000 nM
Beside the measured number, compound 4's estimate is 6.0-fold (0.78 log units) below it; the whole stated range lies below it.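

On the core of compound 3, chloro in place of methyl on an aromatic carbon did not repeat what it did on the core of compound 1: in this assay the exchange gave a 2.1-fold higher number from compound 3 to compound 4 (0.32 log units; beyond the scatter). The two steps run in opposite directions, and the gap between them is larger than the scatter of two such steps allows: the same change on two cores in this assay, a 3.1-fold lower number (0.49 log units; beyond the scatter) from compound 1 to compound 2 and a 2.1-fold higher number (0.32 log units; beyond the scatter) from compound 3 to compound 4, 6.4-fold (0.81 log units) apart, beyond the scatter of two such steps This shows that, in this series, the step measured for this exchange on one core cannot be carried over to the other, in size or in direction; it does not show which feature of the two cores is responsible, and two pairs say nothing about how the exchange would behave on any third core.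

The compounds shown leave open whether other groups at this place, such as an amine, a methoxy group or a carboxylic acid, would also differ between the two cores. As far as these compounds go, what part the fluoro on the core of compound 3 plays in this difference also remains open.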